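This account rests on a few compounds, and the source may have more. Where it says the series, first, only, none or still open, it means among the compounds named here.

Compound 1 `O=C(NCc1ccc(F)cc1)c1nc(Br)c2cccnc2c1NCCO`: 232000 nM
Compound 2 `C[C@@H](CO)Nc1nc(C(=O)NCc2ccc(F)cc2)c(O)c2ncccc12`: 107000 nM

In a toxicity assay on C8166 cells (Homo sapiens) for cytotoxicity, read by MTT assay, with a stated time of 72 h (a higher number here means that more compound is tolerated, a lower number that less compound is tolerated), compound 1 holds the higher of the two numbers at 232000 nM. Its nearest and only neighbour, compound 2, gives 107000 nM, a gap that lies beyond the usual scatter.

Compound 3 `Cc1ccc(S(=O)(=O)Oc2c(C(=O)NCc3ccc(F)cc3)nc(Br)c3cccnc23)cc1` has not yet been measured. It keeps the core of compound 1, but ((4-methylphenyl)sulfonyl)oxy stands in place of (2-hydroxyethyl)amino on an aromatic carbon, para to a bromo group (((4-methylphenyl)sulfonyl)oxy in place of (2-hydroxyethyl)amino on an aromatic carbon). The entering group brings one six-membered aromatic ring of carbon only, which the leaving group lacks.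

Among the compounds with values here, no measured pair shows this exchange, so the data give no direct guide to its size, and any expectation is loose. With compound 1 at the top of the two numbers, at 232000 nM, a move downward seems more likely than a move upward. The expected change is a 4.6-fold lower number from compound 1 to compound 3 (0.67 log units; beyond the scatter), a step beyond the scatter towards less compound tolerated. For compound 3 the estimated value is 50000 nM, with an expected range from 10000 nM to 200000 nM.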

Compound 3, half-maximal cytotoxic concentration: 31000 nM
Estimate against measurement, compound 3: 1.6-fold (0.21 log units) above; the measured number falls inside the stated range.
By their numbers in this assay, from the lowest: compound 3; then compound 2; then compound 1.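

Replacing the (2-hydroxyethyl)amino group of compound 1 with ((4-methylphenyl)sulfonyl)oxy, on the aromatic carbon para to a bromo group, gives in this assay a 7.5-fold lower number from compound 1 to compound 3 (0.87 log units; beyond the scatter), which shows that the number responds to what this carbon carries. This single-place comparison was not available from the earlier pair, and here less compound is tolerated once the group with more heavy atoms stands on this carbon. The exchange removes both hydrogen-bond donors of the leaving group and brings in a six-membered aromatic ring of carbon only, so several features change together and the step cannot be assigned to any one of them, while nothing measured here bears on its cause.

Compound 2 differs from compound 1 in more than one place, so its number adds nothing to this particular exchange. Going by these compounds, whether a methanesulfonyloxy group, which lacks the aromatic ring, or a plain amine on this carbon would move the number in the same direction remains open.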